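Swapping the trihydroxyphenyl group of compound 2 for imidazolyl

The source may report more compounds than this note shows. Statements on the series, on what has been measured and on what is new or still open speak of the compounds shown alone.

Within the data shown here, in a functional assay on P388 cells (Mus musculus) for cytotoxicity (on this read-out lower numbers stand for stronger inhibition and higher numbers for weaker inhibition), compound 1 (`Cc1cc(-c2c(F)cc3c(=O)c(C(=O)O)cn(C4CC4)c3c2F)cc(C)n1`) gives 29000 nM and compound 2 (`Cc1cc(-c2c(F)cc3c(=O)c(Cc4c(O)cc(O)cc4O)cn(C4CC4)c3c2F)cc(C)n1`) gives 470 nM as the lower of the only two numbers so far. Among the measured compounds shown here, the one measured step is a 62-fold lower number from compound 1 to compound 2 (1.79 log units; beyond the scatter) and it came with 2,4,6-trihydroxybenzyl in place of carboxy on an aromatic carbon. Compound 3 (`Cc1cc(-c2c(F)cc3c(=O)c(Cc4c[nH]cn4)cn(C4CC4)c3c2F)cc(C)n1`) carries a further change, reading 1H-imidazol-4-yl in place of 2,4,6-trihydroxyphenyl on a saturated chain carbon bound to an aromatic carbon (1H-imidazol-4-yl in place of 2,4,6-trihydroxyphenyl). For the measured compounds named here, no measured compound carries this new group, so the evidence is indirect. Compound 3 keeps a ring on the saturated chain carbon, yet it gives up the trihydroxyphenyl group present when a 62-fold lower number from compound 1 to compound 2 (1.79 log units; beyond the scatter) was seen, so part of that gain is expected to be lost. In this assay the expected change is a 3.8-fold higher number from compound 2 to compound 3 (0.58 log units; beyond the scatter) (a moderate move towards a higher number). The estimate for compound 3 is 1800 nM (range 350 nM to 9000 nM).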

Compound 3, half-maximal inhibitory concentration: 390 nM
Beside the measured number, compound 3's estimate is 4.6-fold (0.66 log units) above it, within the range that was stated.
By their numbers in this assay, from the lowest: compounds 3 and 2 (each within the scatter of the next); then compound 1.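

In this assay, 1H-imidazol-4-yl in place of 2,4,6-trihydroxyphenyl on a saturated chain carbon bound to an aromatic carbon gives a 1.2-fold lower number from compound 2 to compound 3 (0.08 log units; within the scatter), so this read-out does not separate the two rings, although the entering group has fewer heavy atoms and hydrogen-bond donors. Measured against carboxy, (1H-imidazol-4-yl)methyl gives a 74-fold lower number from compound 1 to compound 3 (1.87 log units; beyond the scatter), which shows that the large step seen earlier does not depend on the 2,4,6-trihydroxybenzyl group alone, since two different ring-bearing groups at this position share it. No supporting data are available to explain this result. The compounds shown leave open whether a ring is needed here at all, which a plain methyl or an aminomethyl group in place of carboxy would address. They also leave open whether an unsubstituted phenyl on the chain carbon would read like these two rings.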